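Chalcone series: aryl swap from compound 3 to compound 4

The source may hold more compounds than are shown below. What is called first, only, known or untested is meant among the compounds shown, and "the series" means these compounds.

Three compounds have numbers in a functional assay on CNE-2 cells (Homo sapiens) for cytotoxicity, read by sulforhodamine B assay, with a stated time of 48 h; a lower number here means a stronger inhibitor, a higher number a weaker inhibitor. Compound 1 `COc1ccc(/C=C/C(=O)c2ccc(N)c(-c3ccc(F)cc3)c2)cc1OC` gives 3510 nM. Compound 2 `O=C(/C=C/c1cccc(-c2ccc(F)cc2)c1)c1ccc(O)cc1` gives 5510 nM. Compound 3 `COc1ccc(-c2cc(C(=O)/C=C/c3cc(OC)c(OC)c(OC)c3)ccc2N)cc1OC` gives 4330 nM; on these three numbers compound 3 sits with compound 1 on one side and compound 2 on the other, and both gaps fall within the usual scatter, so nothing separates the three. For the measured compounds named here, no pair of them differs in a single place. Compound 4 `COc1cc(/C=C/C(=O)c2ccc(N)c(-c3ccc(F)cc3)c2)cc(OC)c1OC` is not yet measured and differs from compound 3 in one place: 4-fluorophenyl in place of 3,4-dimethoxyphenyl on an aromatic carbon. Compound 1 carries the same 4-fluorophenyl and gives 3510 nM, within the scatter of compound 3, so no step beyond the scatter is expected here. The expected step is a 1.1-fold lower number from compound 3 to compound 4 (0.06 log units; within the scatter). Compound 4 is estimated at 3800 nM, with a range from 1500 nM to 9500 nM.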

Compound 4, half-maximal inhibitory concentration: 4600 nM
For compound 4 the middle estimate is 1.2-fold (0.08 log units) below the measured one, within the range that was stated.
By their numbers in this assay, from the lowest: compounds 1, 3, 4 and 2 (each within the scatter of the next).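

For the compounds shown here, at this position, on an aromatic carbon ortho to an amino group, 4-fluorophenyl in place of 3,4-dimethoxyphenyl gives in this assay a 1.1-fold higher number from compound 3 to compound 4 (0.03 log units; within the scatter), the first single-place reading for this aryl swap. On the other aryl ring, methoxy in place of hydrogen gives a 1.3-fold higher number from compound 1 to compound 4 (0.12 log units; within the scatter), so neither change separates the compounds. No measurement bears on what lies behind these numbers.

Still open, from the compounds shown here alone, is whether a carboxylic acid or a morpholine in place of the 4-fluorophenyl would give a step beyond the scatter. The same question stands for a hydroxyl in place of the added methoxy.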